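The source may hold more compounds than are shown below. What is called first, only, known or untested is meant among the compounds shown, and "the series" means these compounds.

Compound 1 `Cc1ccc(-c2nc(CNc3ccc(C(=O)NO)cc3)n(-c3ccccc3)n2)cc1`: 62.2%
Compound 2 `O=C(NO)c1ccc(NCc2nc(-c3ccc(Br)cc3)nn2-c2ccccc2)cc1`: 54.7%
Compound 3 `O=C(NO)c1ccc(NCc2nc(-c3ccccc3)nn2-c2ccccc2)cc1`: 72.6%

These three compounds were tested in an assay on Sf9 cells for inhibition of protein deacetylase HDAC6 (Homo sapiens), read by fluorescence, with a stated time of 40 min, tested at 100 nM; a higher number here means more inhibition at the concentration tested (going by the name of the read-out), a lower number less inhibition. Compound 3 stands highest of the three: the step of a number 10.4 percentage points higher from compound 1 to compound 3 (beyond the scatter) and the step of a number 17.9 percentage points higher from compound 2 to compound 3 (beyond the scatter) both lie beyond the scatter, whereas a number 7.5 percentage points lower from compound 1 to compound 2 (within the scatter) falls within it, so compound 1 and compound 2 cannot be ordered against each other.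

Compound 4 `CC(C)c1ccc(-c2nc(CNc3ccc(C(=O)NO)cc3)n(-c3ccccc3)n2)cc1` has not yet been measured in this assay. It differs from compound 3 by isopropyl in place of hydrogen on an aromatic carbon. Among the measured compounds shown here, the steps that bear on this change are the two that lead into compound 3, in which a methyl or a bromo at this aromatic carbon gave way to hydrogen and the number rose by a modest amount in each case. Read in the opposite direction, putting a group onto this carbon lowered the number. A decrease of similar, modest size is therefore expected for compound 4, a number 16.6 percentage points lower from compound 3 to compound 4 (beyond the scatter). Compound 4 is estimated at 56%, with a range from 40% to 70%.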

Compound 4, a percentage reported as inhibition, at one concentration (the size of the read-out at that concentration, not a potency): 27.6%
Compound 4: the middle estimate sits 28.4 percentage points above what was measured; the whole stated range lies above it.
By their numbers in this assay, from the lowest: compound 4; then compounds 2 and 1 (each within the scatter of the next); then compound 3.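

In this assay, a group on this aromatic carbon, para to a large group, does not carry one fixed cost: isopropyl gives a number 45 percentage points lower from compound 3 to compound 4 (beyond the scatter), well past the modest steps seen when methyl or bromo stood in place of hydrogen. Isopropyl also sets itself apart from those two groups, with a number 27.1 percentage points lower from compound 2 to compound 4 (beyond the scatter) and a number 34.6 percentage points lower from compound 1 to compound 4 (beyond the scatter), whereas methyl and bromo could not be ordered against each other, so the identity of the group counts here and not only whether one is present. Nothing available explains why isopropyl behaves differently from methyl or bromo at this carbon.

The compounds shown leave open how an ethyl group, a tert-butyl group, a methoxy group or an amine would read at this carbon, and so whether the fall sets in abruptly at isopropyl or builds gradually. They also leave open whether these differences would hold as differences in potency, since each number comes from a single concentration.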